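The source may report more compounds than this note shows. Statements on the series, on what has been measured and on what is new or still open speak of the compounds shown alone.

Measured so far:
- Compound 1, `Cc1cc(COc2ccc(-c3ccc(Cl)cc3)cc2)cc(CN2CCN(c3ccncc3)C2=O)c1`, in an ADME assay on cells (Homo sapiens) for cytotoxicity; on this read-out lower numbers stand for higher toxicity in this test and higher numbers for lower toxicity in this test: > 25000 nM
- Compound 2, `O=C1N(CCC(CCOc2ccc(-c3ccc(Cl)cc3)cc2)C(F)(F)F)CCN1c1ccncc1`, in this assay: > 12500 nM

Compound 1 gives > 25000 nM, which is a limit of this assay and not a measured number. Compound 2 likewise gives only > 12500 nM, again a limit of this assay. So compound 2 stands at the limit of > 12500 nM in this assay, at which 1 of the 2 values shown sits, while the one other value known sits at the limit of > 25000 nM in this assay, at which 1 of the 2 values shown sits; neither compound shows toxicity within the range this assay covers, and the two cannot be ordered against each other.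

Compound 3, `O=C1N(CCC(CCOc2ccc(-c3ccc(Cl)cc3)cc2)c2ccccc2)CCN1c1ccncc1`, is the next compound to be measured in this assay. It differs from compound 2 in one place: phenyl in place of trifluoromethyl on a saturated chain carbon bound to two saturated chain carbons. Going by the values given here, no measured pair shows what such a change does in this assay, so the step is expected to be none beyond the usual scatter, and compound 3 is expected to give 25000 nM, the step that the limit leaves unreadable from compound 2 to compound 3, most likely reported once more only as a limit.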

Compound 3, half-maximal cytotoxic concentration: > 25000 nM
Compound 3: a limit, no number; the forecaster's own chance of this, stated with the estimate: 70%; the middle value lies on the limit itself.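

In this assay compound 3 gives > 25000 nM, which is a limit and not a number. Compound 2 also stands only at a limit, so no step can be read from compound 2 to compound 3. The compounds shown leave open at what concentration any of them becomes toxic to the cells, and whether phenyl in place of trifluoromethyl changes that concentration.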